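The source may report more compounds than this note shows. Statements on the series, on what has been measured and on what is new or still open speak of the compounds shown alone.

Compound 1, `C=CC[N+](C)(C)c1cccc(OC)c1`, in a functional assay with Cavia porcellus as the target (on this read-out higher numbers stand for weaker inhibition and lower numbers for stronger inhibition), gives > 3000 nM, which is a limit of the assay and not a number.
Compound 2, `C[N+](C)(Cc1ccccc1)c1cccc(O)c1`, in this assay gives > 3000 nM, again a limit rather than a number.

So the position of compound 2 is only known as a limit: its inhibition was too weak for a number to be read within the range of this assay. Among the compounds with values here, the same holds for the one other value shown, as the limit of > 3000 nM in this assay, at which 2 of the 2 values shown sit, records, so no measured step between two numbers exists here, and nothing can be said about the size or direction of any step from the data themselves.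

Compound 3, `COc1cccc([N+](C)(C)Cc2ccccc2)c1`, is the next compound. It differs from compound 2 by methyl in place of hydrogen on an oxygen on an aromatic ring, so that the free hydroxy group of compound 2 becomes a methoxy group in compound 3.

Within the data shown here, with no measured step to lean on, the expectation for compound 3 is that its inhibition stays weak, and the step from compound 2 to compound 3 is expected to be a step that the limit leaves unreadable from compound 2 to compound 3, which is no move beyond the usual scatter. Compound 3 is therefore expected to come out near 5000 nM, within 1500 nM to 20000 nM, most likely again as a limit.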

Compound 3, half-maximal inhibitory concentration: > 3000 nM
Compound 3: a limit, no number (the forecaster's own chance of this, stated with the estimate: 75%); the middle value does not contradict the limit.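

In this assay compound 3 gives > 3000 nM, which is a limit of the assay and not a number. The steps from compound 1 and from compound 2 to compound 3 therefore cannot be read: the limit of > 3000 nM in this assay, at which 3 of the 3 values shown sit.

The compounds shown leave open how strongly any of the three inhibits, and whether going from hydroxy to methoxy changes that at all.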